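A few compounds are considered here, and "the series" means these few. Any claim that something is new, unique, unknown or untested is made for them only; others in the source may bear on it.

Three cyclic peptides have been measured in an assay on COS-7 cells for inhibition of disintegrin and metalloproteinase domain-containing protein 8 (Homo sapiens), read by ELISA, with a stated time of 6 h; on this read-out higher numbers stand for weaker inhibition and lower numbers for stronger inhibition. Compound 1 `CC(C)C[C@@H]1NC(=O)[C@H](CCCNC(=N)N)NC(=O)[C@H](CCCCN)NC(=O)[C@H](CC(=O)O)NC(=O)[C@H](CCCCN)NC(=O)[C@H](CO)NC1=O` gives 240 nM. Compound 2 `CC(C)C[C@@H]1NC(=O)[C@H](CCCNC(=N)N)NC(=O)[C@H](CCCCN)NC(=O)[C@H](CC(=O)O)NC(=O)[C@H](CCCCN)NC(=O)CCNC1=O` gives 1650 nM, the highest number of the three. Compound 3 `CC(C)(C)C[C@@H]1NC(=O)[C@H](CCCNC(=N)N)NC(=O)[C@H](CCCCN)NC(=O)[C@H](CC(=O)O)NC(=O)[C@H](CCCCN)NC(=O)CCNC1=O` gives 256 nM. Going by the values given here, the only measured step that alters a single place is a 6.4-fold lower number from compound 2 to compound 3 (0.81 log units; beyond the scatter), in which a methyl is added on a saturated chain carbon bound to three saturated chain carbons.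

Compound 4 `CCC[C@@H]1NC(=O)[C@H](CCCNC(=N)N)NC(=O)[C@H](CCCCN)NC(=O)[C@H](CC(=O)O)NC(=O)[C@H](CCCCN)NC(=O)CCNC1=O` has not yet been measured. It differs from compound 2 by hydrogen in place of methyl on a saturated chain carbon bound to two saturated chain carbons, so the same kind of change runs in the opposite direction: a methyl is taken away rather than added. The step from compound 2 to compound 3 showed that adding a methyl gave a clearly lower number; removing one is therefore expected to give a higher number, although with a single step to lean on the size is uncertain. For compound 4 the estimate in this assay is 3500 nM, within a range from 1200 nM to 10000 nM, meaning a step of a 2.1-fold higher number from compound 2 to compound 4 (0.33 log units; beyond the scatter) is expected.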

Compound 4, half-maximal inhibitory concentration: 452 nM
Estimate against measurement, compound 4: 7.7-fold (0.89 log units) above, and the stated range ends above it.
By their numbers in this assay, from the lowest: compounds 1, 3 and 4 (each within the scatter of the next); then compound 2.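

In this assay, taking a methyl away at this position gives a 3.7-fold lower number from compound 2 to compound 4 (0.56 log units; beyond the scatter), the same direction as adding one, which gave a 6.4-fold lower number from compound 2 to compound 3 (0.81 log units; beyond the scatter). Compound 2, with its isobutyl group, therefore reads higher than both compound 3 and compound 4, so the number does not rise or fall steadily with the size of the group across these three compounds, and the remaining step, a 1.8-fold higher number from compound 3 to compound 4 (0.25 log units; within the scatter), lies within the scatter, leaving compound 3 and compound 4 indistinguishable. Nothing available here explains this result.

From the compounds shown here alone, how a longer chain, a phenyl ring, an amine or a carboxylic acid on this carbon would read remains open. Also open, going by these compounds, is whether the same methyl changes would give similar steps on the core of compound 1.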